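A few compounds are considered here, and "the series" means these few. Any claim that something is new, unique, unknown or untested is made for them only; others in the source may bear on it.

Of the compounds shown here, three have been read in a functional assay on CHO cells for agonist activity at Free fatty acid receptor 1 (Homo sapiens), read by a luciferase reporter; a higher number here means a larger maximal response, a lower number a smaller maximal response. Compound 1 `O=C(O)c1ccc(NCc2cccc(Oc3ccccc3)c2)cc1` gives 86%, the highest of the three numbers. Compound 2 `Cc1nc(-c2ccc(C(F)(F)F)cc2)sc1CNc1ccc(CC(=O)O)cc1` gives 18%, and compound 3 `Cc1nc(-c2ccc(C(F)(F)F)cc2)sc1CNc1ccc(CCCC(=O)O)cc1` gives 44%; compound 3 lies nearest to compound 1, and both gaps to compound 1 are beyond the scatter. Going by the values given here, the only single-place step measured so far is a number 26 percentage points higher from compound 2 to compound 3 (beyond the scatter), where the change was 2-carboxyethyl in place of carboxy on a saturated chain carbon bound to an aromatic carbon.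

Compound 4 `O=C(O)/C=C/c1ccc(NCc2cccc(Oc3ccccc3)c2)cc1` differs from compound 1 as follows: 2-carboxyethenyl in place of carboxy on an aromatic carbon. The step from compound 2 to compound 3 bears on this as the one lengthening of the chain bearing the carboxy that has been measured, though it sits on a different core and that chain is saturated. That precedent points toward a response no lower than that of compound 1, but compound 1 already stands high, so little room for a rise beyond the scatter is expected. The step expected is a number 4 percentage points higher from compound 1 to compound 4 (within the scatter). For compound 4 in this assay the estimate is 90%, within 65% to 115%.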

Compound 4, largest response reached (reported as percent of maximum), in percent of the reference or control that the assay uses: 76%
For compound 4 the middle estimate is 14 percentage points above the measured one, within the range that was stated.
By their numbers in this assay, from the lowest: compound 2; then compound 3; then compounds 4 and 1 (each within the scatter of the next).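

On the core of compound 1, at the aromatic carbon para to a large group, 2-carboxyethenyl in place of carboxy gives a number 10 percentage points lower from compound 1 to compound 4 (within the scatter) in this assay. The maximal response at this position therefore holds through this change, with the acid carried on a longer, unsaturated chain. Going by these compounds alone, the only earlier chain step, a number 26 percentage points higher from compound 2 to compound 3 (beyond the scatter), lies beyond the scatter, but it sits on a different core and a saturated chain, so the two steps show that a change in the chain bearing the acid does not read the same in both settings; no available measurement explains this result.

Open, as far as these compounds go, is how a saturated 2-carboxyethyl group at this position of the core of compound 1 would read against compound 4. Also open, from the compounds shown here alone, is whether a longer chain or a tetrazole in place of the carboxylic acid keeps the response.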